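Same Swap, Second Core: Expecting Compound 4

The compounds below may be only part of what the source reports. "The series", "measured", "known", "first", "only" and "open" are said of these compounds alone.

Of the compounds shown here, three have been tested in a functional assay on MIA PaCa-2 cells (Homo sapiens) for inhibition, read by MTT assay, with a stated time of 48 h, tested at 10 uM; on this read-out lower numbers stand for less inhibition of growth and higher numbers for more inhibition of growth at the one concentration tested. Compound 1 `O=C(/C=C/c1ccc(OCc2cn(Cc3ccc(Br)cc3)nn2)cc1)c1ccc(Br)cc1` gives 29%. Compound 2 `O=C(/C=C/c1ccc(OCc2cn(Cc3ccccc3F)nn2)cc1)c1ccc(Br)cc1` differs from it by 2-fluorophenyl in place of 4-bromophenyl on a saturated chain carbon bound to an aromatic nitrogen, and in this assay compound 2 gives 28%; the step of a number 1 percentage points lower from compound 1 to compound 2 (within the scatter) is too small to count as a change. Compound 3 `O=C(/C=C/c1ccc(OCc2cn(Cc3ccc(Br)cc3)nn2)cc1)c1ccc([N+](=O)[O-])cc1` carries a different core, set apart from compound 1 by nitro in place of bromo on an aromatic carbon, and in this assay compound 3 gives 17%, a step of a number 12 percentage points lower from compound 1 to compound 3 (beyond the scatter).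

Compound 4 `O=C(/C=C/c1ccc(OCc2cn(Cc3ccccc3F)nn2)cc1)c1ccc([N+](=O)[O-])cc1` has not yet been measured. It stands to compound 3 exactly as compound 2 stands to compound 1: the change is 2-fluorophenyl in place of 4-bromophenyl on a saturated chain carbon bound to an aromatic nitrogen, the same change seen once before, at the same place. Because the earlier step of a number 1 percentage points lower from compound 1 to compound 2 (within the scatter) lay within the scatter, the new step is expected to be about as small, no change at the digits printed from compound 3 to compound 4 (within the scatter). Compound 4 is therefore estimated to give 17% in this assay, with a likely range from 8% to 27%. For the measured compounds named here, only one measured pair shows this change, so the expectation rests on that single comparison.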

Compound 4, percent growth inhibition at one concentration: 22%
For compound 4 the middle estimate is 5 percentage points below the measured one, and the stated range covers the measured number.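

In this assay, the swap of 4-bromobenzyl to 2-fluorobenzyl gives a number 5 percentage points higher from compound 3 to compound 4 (within the scatter), and its two readings on the two cores agree: the same change on two cores in this assay, a number 1 percentage points lower (within the scatter) from compound 1 to compound 2 and a number 5 percentage points higher (within the scatter) from compound 3 to compound 4, 6 percentage points apart, within the scatter of two such steps. The swap of bromo to nitro, read with 2-fluorobenzyl in place, gives a number 6 percentage points lower from compound 2 to compound 4 (within the scatter), and this reading can be set against the earlier one, with which it also agrees: the same change on two cores in this assay, a number 12 percentage points lower (beyond the scatter) from compound 1 to compound 3 and a number 6 percentage points lower (within the scatter) from compound 2 to compound 4, 6 percentage points apart, within the scatter of two such steps. So on these two cores the benzyl swap carries over with no step beyond the scatter, and the nitro swap leaves one step beyond the scatter and one within it, but two pairs at a single concentration do not show that either swap would behave the same way on any other core.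

The compounds shown carry only bromo or nitro in one place and only 4-bromobenzyl or 2-fluorobenzyl in the other. From the compounds shown here alone, whether an amine or a carboxylic acid in either place would move the number beyond the scatter remains open.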